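A Thiophene for a Methoxyphenyl on the Ester Arm

A few compounds are considered here, and "the series" means these few. Any claim that something is new, unique, unknown or untested is made for them only; others in the source may bear on it.

Compound 1 `C=C1C(=O)O[C@H]2CC3=C[C@H](C/C(C)=C/[C@@H](OC(=O)/C=C/c4cccc(OC)c4)[C@H]12)OC3=O` gives 6200 nM in a functional assay on A549 cells (Homo sapiens) for cytotoxicity, read by MTT assay, with a stated time of 48 h; on this read-out higher numbers stand for weaker inhibition and lower numbers for stronger inhibition. Compound 3 `C=C1C(=O)O[C@H]2CC3=C[C@H](C/C(C)=C/[C@@H](OC(=O)CC4CCCCC4)[C@H]12)OC3=O` gives 6900 nM in this assay. Compound 2 `C=C1C(=O)O[C@H]2CC3=C[C@H](C/C(C)=C/[C@@H](OC(=O)CCl)[C@H]12)OC3=O` gives only a limit in this assay, > 10000 nM.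

Compound 1 has the lowest of the two numbers, but compound 3 sits within the scatter of it: a 1.1-fold higher number from compound 1 to compound 3 (0.05 log units; within the scatter). Compound 2 is a limit, not a number (the limit of > 10000 nM in this assay, at which 1 of the 3 values shown sits).

Compound 4 `C=C1C(=O)O[C@H]2CC3=C[C@H](C/C(C)=C/[C@@H](OC(=O)/C=C/c4cccs4)[C@H]12)OC3=O` differs from compound 1 in one place: thiophen-2-yl in place of 3-methoxyphenyl on a double-bonded chain carbon bound to a double-bonded chain carbon. The measured steps, an at least 1.6-fold higher number from compound 1 to compound 2 (0.20 log units; that floor lies within the scatter) and a 1.1-fold higher number from compound 1 to compound 3 (0.05 log units; within the scatter), replace the whole 2-(3-methoxyphenyl)ethenyl arm, so none of them tests a swap of the ring alone. Nothing beyond the scatter is therefore expected: a 1.0-fold higher number from compound 1 to compound 4 (0.02 log units; within the scatter). Compound 4 is estimated at 6500 nM, between 3000 nM and 13000 nM.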

Compound 4, half-maximal inhibitory concentration: 4300 nM
For compound 4 the middle estimate is 1.5-fold (0.18 log units) above the measured one, within the range that was stated.
By their numbers in this assay, from the lowest: compounds 4, 1 and 3 (each within the scatter of the next). At a limit, above all of these: compound 2.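

Unlike the earlier steps, the swap of 3-methoxyphenyl for thiophen-2-yl keeps the ethenyl link and changes the ring alone, and in this assay it stays within the scatter (a 1.4-fold lower number from compound 1 to compound 4 (0.16 log units; within the scatter)), so these two rings are not told apart here. For the compounds shown here, the 2-(thiophen-2-yl)ethenyl arm is also not separated from cyclohexylmethyl (a 1.6-fold lower number from compound 3 to compound 4 (0.21 log units; within the scatter)), and only the step from chloromethyl passes the scatter (an at least 2.3-fold lower number from compound 2 to compound 4 (0.36 log units; beyond the scatter)). Compound 2 stands as a limit, not a number: the limit of > 10000 nM in this assay, at which 1 of the 4 values shown sits.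

Going by these compounds, whether an amine or a carboxylic acid on the ring would shift the number beyond the scatter stays open. So does the effect of a longer chain in place of the ethenyl.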